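Fluoro substitution on the aryl ring of compound 2

The source may report more compounds than this note shows. Statements on the series, on what has been measured and on what is new or still open speak of the compounds shown alone.

Measured so far:
compound 1 `O=C(O)Cc1sc(NCc2ccccc2)nc1-c1ccc(Cl)cc1`: 440 nM
compound 2 `O=C(O)Cc1sc(C(c2ccccc2)c2ccccc2)nc1-c1ccccc1`: 570 nM

In an in vitro assay on HEK385-7 cells for displacement of a labelled ligand from prostaglandin D2 receptor 2 (Homo sapiens) (on this read-out higher numbers stand for weaker inhibition and lower numbers for stronger inhibition), compound 1 gives 440 nM and compound 2 gives 570 nM. Among the compounds with values here, compound 2 carries the higher of the two numbers, yet its only neighbour, compound 1, sits within the scatter of it, so the two values read as one level and no order between them is claimed. The two compounds differ in more than one place, so nothing about any single change can be drawn from their pair.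

Compound 3 `O=C(O)Cc1sc(C(c2ccccc2)c2ccccc2)nc1-c1ccc(F)cc1` is the next compound of the series. It differs from compound 2 by fluoro in place of hydrogen on an aromatic carbon. Within the data shown here, no pair among the measured compounds shows this kind of change, so the size of the step has to be set from general experience with such small single-atom exchanges. The step of a 1.3-fold lower number from compound 2 to compound 3 (0.10 log units; within the scatter) that the estimate means is expected to stay within the scatter, with no clear direction. Compound 3 is accordingly expected at about 450 nM, with a range from 180 nM to 1400 nM.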

Compound 3, half-maximal inhibitory concentration: 8.7 nM
Beside the measured number, compound 3's estimate is 52-fold (1.71 log units) above it, outside the stated range (below it).
By their numbers in this assay, from the lowest: compound 3; then compounds 1 and 2 (each within the scatter of the next).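

In this assay, the exchange of hydrogen for fluoro on an aromatic carbon, para to a large group, gives a 66-fold lower number from compound 2 to compound 3 (1.82 log units; beyond the scatter) and shows that this position is far from neutral. Within the data shown here, the change from phenyl to 4-fluorophenyl adds one heavy atom, with no ring, no hydrogen-bond donor or acceptor and no net charge, yet it is enough for a step well beyond the scatter, and it is the first single change that can be read, as compound 1 and compound 2 differ in more than one place. Nothing at hand bears on what lies behind the size of this step.

As far as these compounds go, it remains open whether the step belongs to fluoro itself or would also come with other groups at this position, such as bromo, methoxy or methyl. Among these compounds, also open is whether fluoro on another aromatic carbon of the same scaffold, or the same exchange on a compound with a different group in place of the one shared by compound 2 and compound 3, would give a step of similar size.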